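The source may hold more compounds than are shown below. What is called first, only, known or untested is meant among the compounds shown, and "the series" means these compounds.

Measured so far:
- compound 1 `C[C@H](NC(=O)c1cccc(-c2ccc(NS(C)(=O)=O)nc2)c1)C(=O)Nc1ccc(Cl)c(C(F)(F)F)c1` — 4660 nM
- compound 2 `C[C@H](NC(=O)c1cccc(-c2cncc(C(=O)NC3CC3)c2)c1)C(=O)Nc1ccc(Cl)c(C(F)(F)F)c1` — 15100 nM

Among the measured compounds shown here, in a functional assay on K562 cells (Homo sapiens) for inhibition, read by MTT assay, with a stated time of 48 h (a lower number here means a stronger inhibitor, a higher number a weaker inhibitor), compound 2 gives 15100 nM, the higher of the two numbers recorded; its nearest neighbour is compound 1, and the single measured step, a 3.2-fold higher number from compound 1 to compound 2 (0.51 log units; beyond the scatter), separates them.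

The next compound, compound 3 `CC(=O)Nc1ccc(-c2cccc(C(=O)N[C@@H](C)C(=O)Nc3ccc(Cl)c(C(F)(F)F)c3)c2)cn1`, is not yet measured. The change is 6-acetamidopyridin-3-yl in place of 5-(cyclopropylcarbamoyl)pyridin-3-yl on an aromatic carbon. For the measured compounds named here, only one measured step bears on it: a 3.2-fold higher number from compound 1 to compound 2 (0.51 log units; beyond the scatter), which swapped a 6-(methanesulfonamido)pyridin-3-yl for a 5-(cyclopropylcarbamoyl)pyridin-3-yl and gave a modest rise. The move to compound 3 largely reverses that swap, returning to a 6-substituted pyridin-3-yl carrying one hydrogen-bond donor, as in compound 1, though with an acetamido group rather than a methanesulfonamido group. Going by these compounds, a step back down toward the value of compound 1 is therefore expected, of roughly the size seen from compound 1 to compound 2, with a wide range because the acetamido group itself is untested. Compound 3 is expected at 6000 nM (range 2500 nM to 15000 nM). The expected step is a 2.5-fold lower number from compound 2 to compound 3 (0.40 log units; beyond the scatter).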

Compound 3, half-maximal inhibitory concentration: 42800 nM
Compound 3: the middle estimate sits 7.1-fold (0.85 log units) below what was measured; the whole stated range lies below it.
By their numbers in this assay, from the lowest: compound 1; then compound 2; then compound 3.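

In this assay, exchanging only methylsulfonyl for acetyl on the nitrogen gives a 9.2-fold higher number from compound 1 to compound 3 (0.96 log units; beyond the scatter), so at this position the group on that nitrogen changes the number by itself, and the two 6-substituted pyridin-3-yl compounds do not sit together, with compound 2 falling between them. The 6-acetamidopyridin-3-yl group also ends up worse than the 5-(cyclopropylcarbamoyl)pyridin-3-yl group it replaces, with a 2.8-fold higher number from compound 2 to compound 3 (0.45 log units; beyond the scatter), although both groups count the same hydrogen-bond donors and acceptors, so those counts alone do not set the value across this pair. Nothing at hand accounts for the ranking of these three compounds.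

Open, going by these compounds, is how far the number follows the group on that nitrogen: a free amine there, or an ethylsulfonyl group in place of methylsulfonyl, would show whether compound 1 is an isolated case or part of a trend. Also open, on these data alone, is whether a carboxylic acid or a longer chain in place of the cyclopropyl on the carbamoyl group would shift the value of compound 2 in either direction.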